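Chain length on the ring nitrogen: propyl to isopropyl

The source may report more compounds than this note shows. Statements on the series, on what has been measured and on what is new or still open speak of the compounds shown alone.

Measured so far in a functional assay on LNCaP cells (Homo sapiens) for inhibition, read by WST assay, with a stated time of 3 days; a higher number here means a weaker inhibitor, a lower number a stronger inhibitor:
compound 1 `CCCn1ccnc1/C=C/C(=O)/C=C/c1coc2ccccc2c1=O` gives 2100 nM
compound 2 `CCCCn1ccnc1/C=C/C(=O)/C=C/c1coc2ccccc2c1=O` gives 2000 nM
compound 3 `CCCCCn1ccnc1/C=C/C(=O)/C=C/c1coc2ccccc2c1=O` gives 1800 nM

The three compounds share one core and differ only in the chain on the ring nitrogen. The steps among them are small: a 1.1-fold lower number from compound 1 to compound 2 (0.02 log units; within the scatter), a 1.2-fold lower number from compound 1 to compound 3 (0.07 log units; within the scatter) and a 1.1-fold lower number from compound 2 to compound 3 (0.05 log units; within the scatter). Compound 3 therefore stands together with compound 2 and compound 1, all three within the scatter of one another, and no order among them can be read from these numbers.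

Compound 4 `CC(C)n1ccnc1/C=C/C(=O)/C=C/c1coc2ccccc2c1=O` is not yet measured. Compared with compound 3 the change is isopropyl in place of pentyl on an aromatic nitrogen. The measured steps bear on it only loosely: lengthening the chain by one or two carbons, as in a 1.1-fold lower number from compound 1 to compound 2 (0.02 log units; within the scatter) and a 1.2-fold lower number from compound 1 to compound 3 (0.07 log units; within the scatter), moved nothing beyond the scatter. An isopropyl on the same nitrogen is not covered by any measured pair, so the expectation rests on the flatness seen so far. For compound 4 a step of a 1.2-fold higher number from compound 3 to compound 4 (0.07 log units; within the scatter) is expected, that is none beyond the scatter. Compound 4 is estimated at 2100 nM, with a range from 1000 nM to 4500 nM.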

Compound 4, half-maximal inhibitory concentration: 1200 nM
The estimate for compound 4 lay 1.8-fold (0.24 log units) above the measured number, and the stated range covers the measured number.
By their numbers in this assay, from the lowest: compounds 4, 3, 2 and 1 (each within the scatter of the next).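

In this assay, the steps of a 1.5-fold lower number from compound 3 to compound 4 (0.18 log units; within the scatter) and a 1.7-fold lower number from compound 2 to compound 4 (0.22 log units; within the scatter) and a 1.8-fold lower number from compound 1 to compound 4 (0.24 log units; within the scatter) show that isopropyl on this aromatic nitrogen stays level with the unbranched chains. The earlier compounds shown here covered only unbranched chains, so the flat picture now extends to a branched group in the same place, next to the ring atom that bears a large group, and the four compounds cannot be put in any order. No data at hand bear on why the numbers stay together here.

Open, as far as these compounds go, is whether any group on this nitrogen would move the number beyond the scatter, for example a chain longer than pentyl, a benzyl, an amine or a carboxylic acid. Also open, from the compounds shown here alone, is whether the same flatness would hold on other cell lines.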